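The source may hold more compounds than are shown below. What is called first, only, known or untested is meant among the compounds shown, and "the series" means these compounds.

The measured compounds and their values:

Compound 1, `O=C(/C=C/c1ccccc1O)CC(=O)/C=C/c1cccc(O)c1O`: 11000 nM
Compound 2, `O=C(/C=C/c1cccc(O)c1)CC(=O)/C=C/c1cccc(O)c1O`: 8200 nM
Compound 3, `O=C(/C=C/c1ccccc1O)/C=C/c1cccc(O)c1O`: 151000 nM

All three were examined in a physicochemical assay for solubility, using the shake flask method, with a stated time of 12 h; on this read-out lower numbers stand for lower solubility and higher numbers for higher solubility. Compound 1 and compound 2 share one core and differ in a single place: 3-hydroxyphenyl in place of 2-hydroxyphenyl on a double-bonded chain carbon bound to a double-bonded chain carbon. That change gave a 1.3-fold lower number from compound 1 to compound 2 (0.13 log units; within the scatter), so the two values cannot be told apart by this measurement. Compound 3 has a different core; how it differs from the core of compound 1 is not broken down here. In this assay compound 3 gives 151000 nM, the highest number of the three, and its gap to compound 1 and to compound 2 lies beyond the scatter.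

Compound 4, `O=C(/C=C/c1cccc(O)c1)/C=C/c1cccc(O)c1O`, has not yet been measured. It stands to compound 3 as compound 2 stands to compound 1: 3-hydroxyphenyl in place of 2-hydroxyphenyl on a double-bonded chain carbon bound to a double-bonded chain carbon. The place of the change is described in the same words for both pairs, so this is the same change made on a different core.

Going by the values given here, the only evidence for what this change does is the step from compound 1 to compound 2, which was within the scatter. On that basis the step from compound 3 to compound 4 is expected to be small as well, about a 1.3-fold lower number from compound 3 to compound 4 (0.10 log units; within the scatter), resting on a 1.3-fold lower number from compound 1 to compound 2 (0.13 log units; within the scatter). Compound 4 is therefore estimated at 120000 nM in this assay, with a likely range from 50000 nM to 300000 nM.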

Compound 4, solubility: 184000 nM
Estimate against measurement, compound 4: 1.5-fold (0.19 log units) below, within the range that was stated.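

In this assay, putting 3-hydroxyphenyl in place of 2-hydroxyphenyl on a double-bonded chain carbon bound to a double-bonded chain carbon gave a 1.2-fold higher number from compound 3 to compound 4 (0.09 log units; within the scatter), and the same change on the core of compound 1 gave a 1.3-fold lower number from compound 1 to compound 2 (0.13 log units; within the scatter). Going by these compounds alone, on both cores, then, the swap produced no difference that this measurement can resolve, and the opposite directions of the two printed numbers carry no meaning, since each step is lost in the ordinary variation between repeats; this agreement across two cores shows only that the change carried over without a detectable step in these two pairs, not that it would do so on every core or that the two groups are interchangeable in other measurements. Nothing available here offers an explanation for this result.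

On these data alone, both pairs exchange one hydroxyphenyl for another, so it remains open whether a phenyl bearing a carboxylic acid or an amine at the same chain carbon would also leave the two cores in step. As far as these compounds go, it also remains open whether the same swap would stay this small on a third core, such as one with a longer chain.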